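The compounds below may be only part of what the source reports. "The series", "measured", "known", "first", "only" and "open" are said of these compounds alone.

In an ADME assay on L6 cells (Rattus norvegicus) for cytotoxicity, read by resazurin assay, with a stated time of 72 h (a higher number here means a weaker inhibitor, a lower number a stronger inhibitor), compound 1 `Clc1ccc(C2CC3(N4CCCCC4)CCNC2C(c2ccc(Cl)c(Cl)c2)C3)cc1Cl` gives 8870 nM and compound 3 `CCOC(=O)CN1CCC2(N(C)C)CC(c3ccc(Cl)cc3)C1C(c1ccc(Cl)cc1)C2` gives 5120 nM, two values that lie within the usual scatter of each other. As far as these compounds go, compound 2 `O=C(O)CN1CCC2(N3CCCCC3)CC(c3ccc(Cl)cc3)C1C(c1ccc(Cl)cc1)C2` bears a carboxymethyl group and has no number: in this assay the entry for compound 2 reads "not determined" (no result reported) and its standing against the other two therefore remains unknown.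

Compound 4 `NC(=O)CN1CCC2(N3CCCCC3)CC(c3ccc(Cl)cc3)C1C(c1ccc(Cl)cc1)C2` differs from compound 2 in one place. The change is amino in place of hydroxy on a carbonyl carbon and it amounts to amino in place of hydroxy on a carbonyl carbon, turning carboxymethyl into carbamoylmethyl.

Among the measured compounds shown here, no two measured compounds here differ in a single place, so no measured step gives the size of this change. With no number for compound 2 there is also no starting value from which to count a step or give it a direction. For the measured compounds named here, the expectation rests only on the two measured neighbours, compound 1 at 8870 nM and compound 3 at 5120 nM in the same assay, and compound 4 is expected to fall in that region, with no step from them beyond the scatter.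

For compound 4 the estimated value is 8000 nM with an expected range from 3000 nM to 25000 nM once it is measured in this assay under the same conditions.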

Compound 4, half-maximal inhibitory concentration: 23800 nM
Beside the measured number, compound 4's estimate is 3.0-fold (0.47 log units) below it; the range from low to high includes it.
By their numbers in this assay, from the lowest: compounds 3 and 1 (each within the scatter of the next); then compound 4.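

In this assay, among the compounds shown here, compound 4 gives 23800 nM, but compound 2 has no number to set against it, so no step from carboxymethyl to carbamoylmethyl can be read. The compounds shown leave open what amino in place of hydroxy on a carbonyl carbon does to this value. Nothing available here bears on the result for compound 4.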